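A few compounds are considered here, and "the series" means these few. Any claim that something is new, unique, unknown or untested is made for them only; others in the source may bear on it.

Measured compounds:
Compound 1, `O=C(Nc1ccccn1)c1ccccc1OCc1ccccc1`: 11700 nM
Compound 2, `O=C(Nc1cccnc1)c1ccccc1OCc1cccc(Cl)c1`: 1400 nM

Of the compounds shown here, two have been measured in an assay on lysate for inhibition of phosphatidylcholine:ceramide cholinephosphotransferase 2 (Homo sapiens), read by HPLC, with stated times of 30 min and 2 h; on this read-out higher numbers stand for weaker inhibition and lower numbers for stronger inhibition. Compound 1 gives 11700 nM in this assay. Compound 2 gives 1400 nM in this assay, the lowest of the two numbers; compound 1 stands higher, and the gap between the two values is beyond the scatter of repeated measurements. Compound 1 and compound 2 differ in more than one place, so no single structural change can be read out of that gap.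

Compound 3, `Cc1cccc(C)c1COc1ccccc1C(=O)Nc1cccnc1`, is not yet measured in this assay. It differs from compound 2 in one place: 2,6-dimethylphenyl in place of 3-chlorophenyl on a saturated chain carbon bound to an oxygen on an aromatic ring. For the measured compounds named here, no measured pair shows what such a change does, so the direction of the step from compound 2 to compound 3 is open. The author expects no step beyond the scatter: the step of a 1.1-fold higher number from compound 2 to compound 3 (0.03 log units; within the scatter) is the estimate, with both a somewhat lower and a somewhat higher number possible. The estimate for compound 3 in this assay is 1500 nM, in a range from 400 nM to 6000 nM.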

Compound 3, half-maximal inhibitory concentration: 890 nM
Compound 3: the middle estimate sits 1.7-fold (0.23 log units) above what was measured, and the stated range covers the measured number.
By their numbers in this assay, from the lowest: compounds 3 and 2 (each within the scatter of the next); then compound 1.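

In this assay, for the compounds shown here, putting 2,6-dimethylphenyl in place of 3-chlorophenyl on the saturated chain carbon bound to an oxygen on an aromatic ring gives a 1.6-fold lower number from compound 2 to compound 3 (0.20 log units; within the scatter) and provides the first change at a single place that can be read. At this position, a group with 8 heavy atoms, all carbon, and a group with 7 heavy atoms, one of them chlorine, cannot be told apart on this read-out, so neither the loss of the chlorine nor the change to a dimethyl pattern produces a step beyond the scatter. No measurement on these compounds accounts for this outcome.

The compounds shown leave open whether this position would tolerate a very different group, such as an amine, a carboxylic acid or a longer chain between the oxygen and the aromatic ring, since both groups compared here are hydrocarbon-like aromatic rings without hydrogen-bond donors or acceptors. They also leave open how much of the gap separating compound 1 from compound 2 belongs to each of the places in which those two compounds differ.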